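The compounds below may be only part of what the source reports. "The series", "measured", "known", "first", "only" and "open" are said of these compounds alone.

Of the compounds shown here, two sharing one core have been measured in a physicochemical assay for lipophilicity, at pH 7.4; on this read-out higher numbers stand for higher lipophilicity and lower numbers for lower lipophilicity. Within the data shown here, compound 1 `COc1ccc2c(c1)C=CN(C)C(=O)[C@@H]2C` gives 4.3, and compound 2 `CCc1ccc2c(c1)C=CN(C)C(=O)[C@@H]2C` gives 5.9, the higher of the two numbers so far. They differ only by ethyl in place of methoxy on an aromatic carbon.

Compound 3 `C[C@H]1C(=O)N(C)C=Cc2cc(OC(CO)CO)ccc21` has not yet been measured. It keeps the shared core and changes that same place, with 2-hydroxy-1-(hydroxymethyl)ethoxy in place of ethyl on an aromatic carbon.

Among the measured compounds shown here, only one measured step bears on this change, and it is large: a number 1.60 log units higher from compound 1 to compound 2 (beyond the scatter). Methoxy and the entering group both attach through oxygen, so that step points to a lower number when ethyl leaves. For the measured compounds named here, the entering group also carries hydrogen-bond donors, and no measured compound has any, so the data do not fix the size of the change. A drop larger than the measured step seems likely, and the expected step is a number 2.70 log units lower from compound 2 to compound 3 (beyond the scatter). For compound 3 the estimated value is 3.2, within an expected range from 2.3 to 4.1.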

Compound 3, distribution coefficient: 1.3
Compound 3: the middle estimate sits 1.90 log units above what was measured; the measured number lies below the stated range.
By their numbers in this assay, from the lowest: compound 3; then compound 1; then compound 2.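

In this assay, this position on the aromatic carbon can move the number much further than the first pair suggested: putting 2-hydroxy-1-(hydroxymethyl)ethoxy in place of ethyl gives a number 4.60 log units lower from compound 2 to compound 3 (beyond the scatter) in a single change, a larger step than the earlier a number 1.60 log units higher from compound 1 to compound 2 (beyond the scatter) between ethyl and methoxy. Attachment through oxygen is not the whole story, since keeping that oxygen and putting 2-hydroxy-1-(hydroxymethyl)ethyl in place of its methyl still gives a number 3.00 log units lower from compound 1 to compound 3 (beyond the scatter) and makes the group beyond the oxygen matter here as well. Compound 3 is also the first compound shown with hydrogen-bond donors, but this single change brings in the donors and a longer group together, so their shares of the step cannot be separated.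

No measurement is available here that explains the size of this step.

The compounds shown leave open whether a shorter 2-hydroxyethoxy chain would give a step of similar size. They also leave open how this assay would read for an amine or a carboxylic acid at this same place on the shared core.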